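Para substituent swap on the shared core: butyl to chloro

The source may hold more compounds than are shown below. What is called first, only, known or untested is meant among the compounds shown, and "the series" means these compounds.

Measured so far:
compound 1 `Oc1nc2nonc2nc1Nc1ccc(OCC(F)(F)F)cc1` — 42300 nM
compound 2 `CCCCc1ccc(Nc2nc3nonc3nc2O)cc1` — 2100 nM
compound 3 `CCCCc1ccc(Nc2nc3nonc3nc2O)c(F)c1` — 1100 nM

All three share one core and differ only on the aryl ring carried by the amine. In an assay on mitochondria from L6 cells (Rattus norvegicus) for activation, with a stated time of 90 min (on this read-out lower numbers stand for an effect already at smaller amounts and higher numbers for an effect only at larger amounts of compound), compound 1 gives 42300 nM, compound 2 gives 2100 nM and compound 3 gives 1100 nM. Compound 2 stands second highest of the three numbers: its nearest neighbour is compound 3, which lies within the scatter, a 1.9-fold lower number from compound 2 to compound 3 (0.28 log units; within the scatter), and its furthest is compound 1, a 20-fold lower number from compound 1 to compound 2 (1.30 log units; beyond the scatter).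

Compound 4 is `Oc1nc2nonc2nc1Nc1ccc(Cl)cc1`. Against compound 2 the change is chloro in place of butyl on an aromatic carbon. Going by the values given here, the one measured step that touches the same place is the step from compound 1 to compound 2, a 20-fold lower number from compound 1 to compound 2 (1.30 log units; beyond the scatter), which shows that what sits on this carbon, para to a large group, can move this assay a great deal. The fluoro step to compound 3 sits elsewhere on the ring and says nothing about this carbon. Among the compounds with values here, with only one step to go on and no chloro analogue measured, the direction is open; the working expectation is a moderate rise in number, a 2.9-fold higher number from compound 2 to compound 4 (0.46 log units; beyond the scatter), since the group shrinks from butyl to a single chlorine and compound 1 shows that a less lipophilic-looking substituent is not a guide here. Compound 4 is therefore expected to give about 6000 nM, within 2000 nM to 20000 nM.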

Compound 4, half-maximal effective concentration: 11700 nM
Compound 4: middle estimate off by 2.0-fold (0.29 log units), on the low side, within the range that was stated.
By their numbers in this assay, from the lowest: compounds 3 and 2 (each within the scatter of the next); then compound 4; then compound 1.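

Working notes on the carbon para to a large group: in this assay, three groups at this carbon now separate into three levels, with butyl giving the lowest number, chloro in the middle and 2,2,2-trifluoroethoxy the highest. Replacing butyl costs activity on this read-out, with a 5.6-fold higher number from compound 2 to compound 4 (0.75 log units; beyond the scatter) as the step, so the butyl chain gives a lower number here than a single chlorine does. Yet chloro still improves on the group in compound 1, with a 3.6-fold lower number from compound 1 to compound 4 (0.56 log units; beyond the scatter) as the step, so the number does not simply follow the heavy-atom count of the group, and compound 1 is the one that goes against such a trend.

Still open, from the compounds shown here alone, is how a longer chain such as hexyl, or an amine or a carboxylic acid, would fall on this carbon relative to butyl, and whether the fluoro change seen in compound 3 would carry over to the chloro compound. No measurement in hand bears on why the three groups fall in this order.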